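Carbonyl substituent changes: expectation for compound 4

The source may hold more compounds than are shown below. What is called first, only, known or untested is meant among the compounds shown, and "the series" means these compounds.

Compound 3 `CN(C)c1ccc(C(=O)N2CCC[C@H]2C(=O)N2CCC(NS(=O)(=O)c3cc(S(=O)(=O)c4ccccc4)ccc3C(F)(F)F)CC2)cc1` gives 110 nM in an assay on isolated protein for binding affinity to secreted frizzled-related protein 1 (Homo sapiens), read by fluorescence (a higher number here means a weaker inhibitor, a lower number a stronger inhibitor), the highest of the three numbers but within the scatter of both others: compound 1 `CC(C)(C)OC(=O)N1CCC[C@H]1C(=O)N1CCC(NS(=O)(=O)c2cc(S(=O)(=O)c3ccccc3)ccc2C(F)(F)F)CC1` gives 60 nM and compound 2 `CN(C)CC(=O)N1CCC[C@H]1C(=O)N1CCC(NS(=O)(=O)c2cc(S(=O)(=O)c3ccccc3)ccc2C(F)(F)F)CC1` gives 90 nM. All three steps, a 1.5-fold higher number from compound 1 to compound 2 (0.18 log units; within the scatter), a 1.8-fold higher number from compound 1 to compound 3 (0.26 log units; within the scatter) and a 1.2-fold higher number from compound 2 to compound 3 (0.09 log units; within the scatter), stay within the scatter. Compound 4 `CC(C)(C)NC(=O)N1CCC[C@H]1C(=O)N1CCC(NS(=O)(=O)c2cc(S(=O)(=O)c3ccccc3)ccc2C(F)(F)F)CC1` carries (tert-butyl)amino in place of 4-(dimethylamino)phenyl on a carbonyl carbon. Within the data shown here, the nearest precedent is the step from compound 1 to compound 3 in reverse, tert-butoxy and (tert-butyl)amino being close relatives. No step beyond the scatter is expected, because a 1.8-fold higher number from compound 1 to compound 3 (0.26 log units; within the scatter) and a 1.2-fold higher number from compound 2 to compound 3 (0.09 log units; within the scatter) were both within it, so the expected step is a 1.5-fold lower number from compound 3 to compound 4 (0.17 log units; within the scatter). For compound 4 the estimate in this assay is 75 nM, range 35 nM to 160 nM.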

Compound 4, half-maximal inhibitory concentration: 20 nM
Estimate against measurement, compound 4: 3.8-fold (0.57 log units) above; measured number below the stated range.
By their numbers in this assay, from the lowest: compound 4; then compounds 1, 2 and 3 (each within the scatter of the next).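

The carbonyl position does respond to its substituent in this assay: (tert-butyl)amino on this carbonyl carbon gives steps beyond the scatter against all three earlier compounds (a 5.5-fold lower number from compound 3 to compound 4 (0.74 log units; beyond the scatter)) and (a 4.5-fold lower number from compound 2 to compound 4 (0.65 log units; beyond the scatter)) and (a 3.0-fold lower number from compound 1 to compound 4 (0.48 log units; beyond the scatter)). The last step keeps the tert-butyl and exchanges only tert-butoxy for (tert-butyl)amino, and that single change leaves the scatter. Nothing available accounts for this result.

Still open, on these data alone, is whether the amide hydrogen or the tert-butyl carries the difference. Isopropylamino and (tert-butyl)(methyl)amino on the same carbonyl carbon would separate the two.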